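A few compounds are considered here, and "the series" means these few. Any claim that something is new, unique, unknown or untested is made for them only; others in the source may bear on it.

Compound 1 `CCOC(=O)c1cc2ccc(Oc3ccnc(C(=O)NC)c3)cc2s1`: > 100000 nM
Compound 2 `CNC(=O)c1cc(Oc2ccc3cc(C(=O)OC)sc3c2)ccn1`: 68300 nM
Compound 3 `CCOC(=O)c1sc2cc(Oc3ccnc(C(=O)NC)c3)ccc2c1Cl`: 45600 nM

All three values come from an ADME assay on HeLa cells (Homo sapiens) for cytotoxicity, read by MTT assay, with a stated time of 2 days; on this read-out lower numbers stand for higher toxicity in this test and higher numbers for lower toxicity in this test. For compound 1, > 100000 nM is a limit of the assay and not a number. Compound 1 thus stands at the limit of > 100000 nM in this assay, at which 1 of the 3 values shown sits.

Compound 4 `CCOC(=O)c1cc2ccc(Oc3ccncc3)cc2s1` has not yet been measured. It carries hydrogen in place of methylcarbamoyl on an aromatic carbon.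

Neither measured step touches the methylcarbamoyl group, so both offer only indirect guidance. Shortening the ester chain gave an at least 1.4-fold lower number from compound 1 to compound 2 (0.16 log units; that floor lies within the scatter). Adding chloro to an aromatic carbon gave an at least 2.1-fold lower number from compound 1 to compound 3 (0.34 log units; beyond the scatter). For the measured compounds named here, both sizes are floors, and only the step to compound 3 clears the scatter. They suggest that a single change to this series can bring a measurable number in this assay, so a modest step toward a lower number is expected, though with little certainty. The expected change is an at least 2.0-fold lower number from compound 1 to compound 4 (0.30 log units; that floor lies within the scatter). For compound 4 the estimated value is 50000 nM, with an expected range of 15000 nM to 100000 nM.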

Compound 4, half-maximal cytotoxic concentration: 43900 nM
Compound 4: the middle estimate sits 1.1-fold (0.06 log units) above what was measured; low and high end bracket the measured number.
By their numbers in this assay, from the lowest: compounds 4, 3 and 2 (each within the scatter of the next). At a limit, above all of these: compound 1.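

Replacing the methylcarbamoyl group with hydrogen, on the aromatic carbon next to the ring nitrogen, gives in this assay an at least 2.2-fold lower number from compound 1 to compound 4 (0.35 log units; beyond the scatter). For the compounds shown here, the earlier steps changed only the ester chain or added chloro, so this is the first evidence that the methylcarbamoyl position also affects the read-out, and that the core needs no methylcarbamoyl group to give a measurable number. The true size of the step stays unknown because compound 1 sits at a limit: the limit of > 100000 nM in this assay, at which 1 of the 4 values shown sits.

As far as these compounds go, how a carboxylic acid, an amine or a plain methyl group on this same carbon would read remains open, and these could show whether the whole methylcarbamoyl group matters or only a part of it. Also open, from the compounds shown here alone, is whether hydrogen at this position combined with chloro on the core would give a lower number still.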